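A few compounds are considered here, and "the series" means these few. Any claim that something is new, unique, unknown or untested is made for them only; others in the source may bear on it.

Measured in a functional assay on A-375 cells (Homo sapiens) for cytotoxicity, read by CCK-8 assay, with a stated time of 24 h; a higher number here means a weaker inhibitor, a lower number a stronger inhibitor:
- compound 1 `COc1ccccc1Oc1c(N)nc(-c2ccc(C)cc2)nc1Cl`: > 80000 nM (a limit)
- compound 2 `COc1ccccc1Oc1c(N)nc(-c2cccc(C)c2)nc1OCCO`: 1380 nM

Within the data shown here, compound 2 holds the only actual number so far, at 1380 nM. The one other result belongs to compound 1, and its > 80000 nM is a limit of the assay, not a number.

The next compound, compound 3 `COc1ccccc1Oc1c(N)nc(-c2ccc(C)cc2)nc1OCCO`, has the same atoms as compound 2, joined differently. It carries 4-methylphenyl in place of 3-methylphenyl on an aromatic carbon, between two ring nitrogen atoms (4-methylphenyl in place of 3-methylphenyl on an aromatic carbon). Among the measured compounds shown here, no measured step covers this kind of change, so the expectation rests on compound 2 at 1380 nM and on the small structural shift. In this assay the estimated 1.1-fold higher number from compound 2 to compound 3 (0.04 log units; within the scatter) is expected to stay within the usual scatter. For compound 3 the expected value is 1500 nM, with an estimated range of 500 nM to 5000 nM.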

Compound 3, half-maximal inhibitory concentration: 2380 nM
For compound 3 the middle estimate is 1.6-fold (0.20 log units) below the measured one; the measured number falls inside the stated range.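

In this assay, shifting the methyl group of the aryl ring on the aromatic carbon between two ring nitrogen atoms, with 4-methylphenyl in place of 3-methylphenyl, gives a 1.7-fold higher number from compound 2 to compound 3 (0.24 log units; within the scatter), so the two placements are not told apart. With 4-methylphenyl held fixed, 2-hydroxyethoxy in place of chloro gives an at least 33-fold lower number from compound 1 to compound 3 (1.52 log units; beyond the scatter), a far larger step than the methyl shift. The result for compound 1, > 80000 nM, is a limit and not a number, so the true size of that step stays unknown: the limit of > 80000 nM in this assay, at which 1 of the 3 values shown sits.

As far as these compounds go, it remains open whether an unsubstituted phenyl or a 2-methylphenyl group on the same carbon would fall in the same range. From the compounds shown here alone, it is also open whether a longer chain such as 3-hydroxypropoxy, a 2-methoxyethoxy group or an amine could stand in for 2-hydroxyethoxy.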